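Swapping a Bromobenzyl Arm for a Bromo-Methoxy Variant

The source may report more compounds than this note shows. Statements on the series, on what has been measured and on what is new or still open speak of the compounds shown alone.

Compound 1 `COc1cc(N(Cc2ccc(Br)cc2)C(=O)CSc2nc3ccccc3s2)cc(OC)c1OC` was tested in a functional assay on PC-3 cells (Homo sapiens) for antiproliferative activity, read by MTT assay, with a stated time of 48 h (on this read-out higher numbers stand for weaker inhibition and lower numbers for stronger inhibition), and gives > 80000 nM, which is a limit of the assay rather than a measured number. It therefore stands at the limit of > 80000 nM in this assay, at which 1 of the 2 values shown sits, with no finer placement possible. Among the measured compounds shown here, compound 2 `COc1ccc(CN(C(=O)CSc2nc3c(C)cccc3s2)c2cc(OC)c(OC)c(OC)c2)cc1O`, the only other measured compound, gives 12300 nM in this assay. Compound 3 `COc1ccc(CN(C(=O)CSc2nc3ccccc3s2)c2cc(OC)c(OC)c(OC)c2)cc1Br` carries 3-bromo-4-methoxyphenyl in place of 4-bromophenyl on a saturated chain carbon bound to an amide-type nitrogen. For the measured compounds named here, no measured step between close neighbours is available, so the expectation rests on these two values alone: a moderate gain is expected, as an at least 2.6-fold lower number from compound 1 to compound 3 (0.42 log units; beyond the scatter). Compound 3 is estimated at 30000 nM, within 8000 nM to 90000 nM.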

Compound 3, half-maximal inhibitory concentration: 16000 nM
Compound 3: the middle estimate sits 1.9-fold (0.27 log units) above what was measured; the measured number falls inside the stated range.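

Among the compounds shown here, replacing 4-bromophenyl with 3-bromo-4-methoxyphenyl on a saturated chain carbon bound to an amide-type nitrogen gives the first readable single-place step in this assay: an at least 5.0-fold lower number from compound 1 to compound 3 (0.69 log units; beyond the scatter). This position therefore responds to a change of substituents while the rest of the molecule stays fixed. The true size of the step is unknown because the value of compound 1 is a limit: the limit of > 80000 nM in this assay, at which 1 of the 3 values shown sits.

The compounds shown do not separate the effect of the methoxy from that of the new bromine placement. From the compounds shown here alone, how an amine or a carboxylic acid on this phenyl ring would read also stays open.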